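The source may hold more compounds than are shown below. What is called first, only, known or untested is meant among the compounds shown, and "the series" means these compounds.

Four compounds share one core: compound 1 (`COc1cc(OC)c(OC)cc1/C=C/COC(=O)/C=C/c1ccc(OC)c(OC)c1`), compound 2 (`COc1cc(OC)c(OC)cc1/C=C/COC(=O)/C=C/c1cc(OC)c(OC)c(OC)c1OC`), compound 3 (`COc1cc(OC)c(OC)cc1/C=C/COC(=O)/C=C/c1ccc(Br)cc1`) and compound 4 (`COc1cc(OC)c(OC)cc1/C=C/COC(=O)/C=C/c1cc(OC)c(OC)c(OC)c1`). In a functional assay on the whole organism (strain Kunming) with Mus musculus as the target, with a stated time of 0.5 h (on this read-out higher numbers stand for an effect only at larger amounts of compound and lower numbers for an effect already at smaller amounts), compound 1 gives 58.1 mg/kg, compound 3 gives 61.8 mg/kg and compound 2 gives 30.9 mg/kg, a number within the scatter of both others. Compound 4 differs from compound 2 as follows: hydrogen in place of methoxy on an aromatic carbon. That is hydrogen in place of methoxy on an aromatic carbon. The only measured step between two of these compounds, a 1.1-fold higher number from compound 1 to compound 3 (0.03 log units; within the scatter), stays within the scatter, and no measured step removes a single methoxy. In this assay the expected change is therefore no larger than the scatter, namely a 1.3-fold higher number from compound 2 to compound 4 (0.11 log units; within the scatter). For compound 4 the estimated value is 40 mg/kg, with an expected range of 22 mg/kg to 72 mg/kg.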

Compound 4, dose for half-maximal effect: 33.2 mg/kg
The estimate for compound 4 lay 1.2-fold (0.08 log units) above the measured number; the measured number falls inside the stated range.
By their numbers in this assay, from the lowest: compounds 2, 4, 1 and 3 (each within the scatter of the next).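

In this assay, among the compounds shown here, the methoxy ortho to a large group can be replaced by hydrogen with only a 1.1-fold higher number from compound 2 to compound 4 (0.03 log units; within the scatter), the first measured step that removes a single methoxy. Adding a methoxy on an aromatic carbon of compound 1 gives a 1.8-fold lower number from compound 1 to compound 4 (0.24 log units; within the scatter), so neither single methoxy change exceeds the scatter. No supporting measurement bears on these steps.

As far as these compounds go, it remains open whether a larger change at this aromatic carbon, such as an amine or a carboxylic acid in place of the methoxy, would move the number beyond the scatter.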